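The source may report more compounds than this note shows. Statements on the series, on what has been measured and on what is new or still open speak of the compounds shown alone.

Measured compounds:
compound 1 `Cc1ccc(-c2noc(CCCCCCC(=O)NO)n2)cc1` — 15800 nM
compound 2 `O=C(CCCCCCc1nc(-c2ccc(C(F)(F)F)cc2)no1)NO` — 15300 nM
compound 3 `O=C(CCCCCCc1nc(-c2ccc(F)cc2)no1)NO` — 19400 nM

In a functional assay on NCI-H661 cells (Homo sapiens) for antiproliferative activity, read by MTT assay, with a stated time of 72 h (a lower number here means a stronger inhibitor, a higher number a weaker inhibitor), the three measured compounds differ only in the group on the aromatic carbon, and every step among them stays within the scatter: a 1.0-fold lower number from compound 1 to compound 2 (0.01 log units; within the scatter), a 1.2-fold higher number from compound 1 to compound 3 (0.09 log units; within the scatter), a 1.3-fold higher number from compound 2 to compound 3 (0.10 log units; within the scatter). Compound 2 holds the lowest number of the three, but its gap to compound 1 and to compound 3 is within the scatter, so no order among them can be read from these numbers.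

Compound 4 `Nc1ccccc1NC(=O)CCCCCCc1nc(-c2ccc(C(F)(F)F)cc2)no1` keeps the trifluoromethyl-bearing aryl and the shared core of compound 2 and changes the chain end: 2-aminophenyl in place of hydroxy on an amide-type nitrogen. Cut one bond further out, hydroxycarbamoyl becomes (2-aminophenyl)carbamoyl. For the measured compounds named here, none of the measured steps touches this position; all three swap only the aryl substituent and were within the scatter, so they give no measure of the hydroxy-to-2-aminophenyl change. The expectation rests on the structural change alone and is set wide, leaning toward a higher number, because compound 2 already stands at 15300 nM with little room for the change to read as a clear gain. For compound 4 the estimate is 25000 nM, range 6000 nM to 100000 nM, meaning an expected step of a 1.6-fold higher number from compound 2 to compound 4 (0.21 log units; within the scatter).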

Compound 4, half-maximal inhibitory concentration: 29800 nM
Compound 4: middle estimate off by 1.2-fold (0.08 log units), on the low side, and the stated range covers the measured number.
By their numbers in this assay, from the lowest: compounds 2, 1, 3 and 4 (each within the scatter of the next).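

In this assay, for the compounds shown here, this is the first reading at the chain end rather than on the aryl substituent: a 1.9-fold higher number from compound 2 to compound 4 (0.29 log units; within the scatter), for 2-aminophenyl in place of hydroxy on an amide-type nitrogen. On the trifluoromethyl-bearing aryl, hydroxycarbamoyl and (2-aminophenyl)carbamoyl therefore cannot be told apart in this read-out, even though the entering group brings 7 heavy atoms and a six-membered aromatic ring where the leaving group has 1 heavy atom and no ring. No supporting data bear on this result.

From the compounds shown here alone, whether the same swap also stays within the scatter on the methyl-bearing aryl of compound 1 or the fluoro-bearing aryl of compound 3 remains open. Also open, going by these compounds, is whether a carboxylic acid at the chain end, or a longer chain, would give a step beyond the scatter.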